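Naphthalenyl to Chlorophenyl on a Shared Core

This account rests on a few compounds, and the source may have more. Where it says the series, first, only, none or still open, it means among the compounds named here.

Compound 1 `Brc1cn2ccnc2c(-c2ccc3ncn(C4CCCCC4)c3c2)n1` gives 21.3% in a functional assay on SNB-75 cells (Homo sapiens) for inhibition, read by sulforhodamine B assay, with a stated time of 48 h, tested at 10 uM; a higher number here means more inhibition at the concentration tested (going by the name of the read-out), a lower number less inhibition.
Compound 2 `c1ccc2c(-c3cn4ccnc4c(-c4ccc5ncn(C6CCCCC6)c5c4)n3)cccc2c1` gives 16.5% in this assay.

Among the measured compounds shown here, only two compounds carry numbers in this assay. Compound 2 stands at the lowest of the two, its nearest neighbour being compound 1; the step of a number 4.8 percentage points lower from compound 1 to compound 2 (within the scatter) is within the scatter, so the two values cannot be ordered.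

The unmeasured compound 3 `Clc1ccc(-c2cn3ccnc3c(-c3ccc4ncn(C5CCCCC5)c4c3)n2)cc1` differs from compound 2 in one place: 4-chlorophenyl in place of naphthalen-1-yl on an aromatic carbon. For the measured compounds named here, the one measured step that bears on this place, a number 4.8 percentage points lower from compound 1 to compound 2 (within the scatter), swapped bromo for naphthalen-1-yl and stayed within the scatter. Nothing measured here separates a 4-chlorophenyl from either of those groups, so the expected step of a number 2.5 percentage points higher from compound 2 to compound 3 (within the scatter) is taken to be none beyond the scatter, in no firm direction. Compound 3 is therefore estimated at 19%, with a range from 5% to 34%.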

Compound 3, a percentage reported as inhibition, at one concentration (the size of the read-out at that concentration, not a potency): 31.2%
Compound 3: middle estimate off by 12.2 percentage points, on the low side; measured number inside the range.
By their numbers in this assay, from the lowest: compounds 2, 1 and 3 (each within the scatter of the next, the first and the last beyond it).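

Among the compounds shown here, at this position the readout in this assay can respond to the group on the aromatic carbon, which the earlier pair did not show: a number 14.7 percentage points higher from compound 2 to compound 3 (beyond the scatter), with 4-chlorophenyl in place of naphthalen-1-yl, is the first step here to pass the scatter, though only modestly, and the swap leaves one six-membered aromatic ring of carbon only where there were two. The bromo compound does not fall clearly on either side of this: a number 9.9 percentage points higher from compound 1 to compound 3 (within the scatter), so the swap of bromo for 4-chlorophenyl cannot be ordered, and only the difference between the two aryl groups stands out. No measurement shown here explains why these two aryl groups part.

From the compounds shown here alone, it remains open whether the difference follows the chlorine or the single ring, a question that a plain phenyl at this position would help to separate. The compounds shown also leave open how an amine such as morpholine, or a carboxylic acid, would read at this position, and whether any group here can lift the number well clear of the bromo compound.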